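This account rests on a few compounds, and the source may have more. Where it says the series, first, only, none or still open, it means among the compounds named here.

Compound 1 `O=C(N[C@H](CSCc1ccccc1)C(=O)O)[C@@H](CS)Cc1ccccc1` and compound 2 `CC(C)(C)SC[C@@H](NC(=O)[C@@H](CS)Cc1ccccc1)C(=O)O` share a core and differ only in the group carried on the sulfur of the side chain. In an assay on isolated protein for inhibition of Neprilysin (Oryctolagus cuniculus) (a lower number here means a stronger inhibitor, a higher number a weaker inhibitor), compound 1 gives 14 nM; 9 nM (2 entries), and the repeated entries the several entries of compound 1 in this assay, 14 nM; 9 nM (2 entries) show how closely such measurements agree. In this assay, going by the values given here, compound 2 gives 49 nM, which is the only number recorded for it; a further entry for compound 2 carries no single number.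

Compound 3 `CSC[C@@H](NC(=O)[C@@H](CS)Cc1ccccc1)C(=O)O` is not yet measured. It differs from compound 2 by methyl in place of tert-butyl on a sulfur. Among the compounds with values here, no measured pair shows this exact change, so its effect can only be guessed. The expected step from compound 2 to compound 3 in this assay is a 1.2-fold higher number from compound 2 to compound 3 (0.09 log units; within the scatter), small and not beyond the usual scatter. Compound 3 is therefore estimated at 60 nM, with a range from 20 nM to 200 nM.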

Compound 3, half-maximal inhibitory concentration: 1.5 nM
For compound 3 the middle estimate is 40-fold (1.60 log units) above the measured one; measured number below the stated range.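

In this assay, going by these compounds alone, the group on this sulfur matters far more than the earlier compounds could show: replacing tert-butyl with methyl gives a 33-fold lower number from compound 2 to compound 3 (1.51 log units; beyond the scatter). Compound 3, which carries only one carbon on the sulfur, has a printed value of 1.5 nM, which lies below the values of both earlier compounds. This step is far wider than the gap between repeated measurements of one compound: the several entries of compound 1 in this assay, 14 nM; 9 nM (2 entries)

The compounds shown leave open whether the low value is specific to methyl or would survive with an ethyl group or a longer chain on the sulfur. They also do not show what a chain ending in an amine or a carboxylic acid would do there, or why removing the outer carbons of tert-butyl has such a large effect.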